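Moving the fluorine: what to expect for compound 3

The source may hold more compounds than are shown below. What is called first, only, known or untested is meant among the compounds shown, and "the series" means these compounds.

In an ADME assay on Vero cells (Chlorocebus sabaeus) for inhibition (on this read-out lower numbers stand for higher toxicity in this test and higher numbers for lower toxicity in this test), two compounds have been measured so far:
Compound 1 `COc1ccc(/C=C2\CCC/C(=C\c3ccc(Br)cc3)C2=O)cc1` gives 250000 nM
Compound 2 `COc1ccc(/C=C2\CCC/C(=C\c3ccc(F)cc3)C2=O)cc1` gives 378000 nM

Going by the values given here, the only measured step is a 1.5-fold higher number from compound 1 to compound 2 (0.18 log units; within the scatter) and so compound 2 stands level with compound 1, with no ranking possible between them. Compound 3 `COc1ccc(/C=C2\CCC/C(=C\c3ccccc3F)C2=O)cc1` has not yet been measured. Its change from compound 2 is 2-fluorophenyl in place of 4-fluorophenyl on a double-bonded chain carbon bound to a double-bonded ring carbon and the atoms stay the same, joined differently. Among the compounds with values here, no measured step moves a fluorine like this, so the evidence is indirect. The closest guide is the swap of fluoro for bromo that led to compound 2, a small step of a 1.5-fold higher number from compound 1 to compound 2 (0.18 log units; within the scatter) and nothing larger has been seen. In this assay the expected change is therefore a 1.2-fold lower number from compound 2 to compound 3 (0.07 log units; within the scatter) and this estimate foresees nothing beyond the scatter. Compound 3 is expected at about 320000 nM (estimated range 150000 nM to 650000 nM).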

Compound 3, half-maximal cytotoxic concentration: 270000 nM
Compound 3: the middle estimate sits 1.2-fold (0.07 log units) above what was measured, within the range that was stated.
By their numbers in this assay, from the lowest: compounds 1, 3 and 2 (each within the scatter of the next).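

Moving the fluorine from 4-fluorophenyl to 2-fluorophenyl, on a double-bonded chain carbon bound to a double-bonded ring carbon, gives a 1.4-fold lower number from compound 2 to compound 3 (0.15 log units; within the scatter) in this assay and is the first measured shift of this kind. Replacing 4-bromophenyl with 2-fluorophenyl at that same place gives a 1.1-fold higher number from compound 1 to compound 3 (0.03 log units; within the scatter), so neither change separates the three compounds, and a swap of halogen and a shift of fluorine have now both left the number within the scatter. No measurement available here accounts for why these values stay so close.

All three compounds carry a halogen on this aromatic ring. From the compounds shown here alone, whether an amine or a carboxylic acid there would move the number beyond the scatter remains open.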